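An aryl exchange in an antiproliferative series

A few compounds are considered here, and "the series" means these few. Any claim that something is new, unique, unknown or untested is made for them only; others in the source may bear on it.

Compound 1 `CC1(C)CCc2cc(C(=O)/C=C/c3ccc(OCc4cn(-c5ccc(Br)cc5)nn4)cc3)c(O)cc2O1`: 80000 nM
Compound 2 `COc1ccc(-n2cc(COc3ccc(/C=C/C(=O)c4cc5c(cc4O)OC(C)(C)CC5)cc3)nn2)c([N+](=O)[O-])c1`: 99500 nM

Both values come from a functional assay on A549 cells (Homo sapiens) for antiproliferative activity, read by MTT assay; a lower number here means a stronger inhibitor, a higher number a weaker inhibitor. In this assay compound 2 gives 99500 nM, which stands level with compound 1, as the two numbers lie within the scatter of each other.

Compound 3 `CCc1ccccc1-n1cc(COc2ccc(/C=C/C(=O)c3cc4c(cc3O)OC(C)(C)CC4)cc2)nn1` keeps the core of compound 2 and carries 2-ethylphenyl in place of 4-methoxy-2-nitrophenyl on an aromatic nitrogen.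

Within the data shown here, one measured step bears on this exchange, made at the same place: a 1.2-fold higher number from compound 1 to compound 2 (0.09 log units; within the scatter). That step, from 4-bromophenyl to 4-methoxy-2-nitrophenyl, lies within the scatter. It is a single step, however, and neither aryl group measured so far carries an ethyl group, so the data offer only thin support. On that basis, no step beyond the scatter is expected in this assay, in either direction. The expected step is a 1.2-fold lower number from compound 2 to compound 3 (0.09 log units; within the scatter).

For compound 3 the estimated value is 80000 nM, with an expected range from 35000 nM to 150000 nM.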

Compound 3, half-maximal inhibitory concentration: 137000 nM
Compound 3: the middle estimate sits 1.7-fold (0.23 log units) below what was measured; the range from low to high includes it.
By their numbers in this assay, from the lowest: compounds 1, 2 and 3 (each within the scatter of the next).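

Across the three aryl groups now seen on this aromatic nitrogen, this assay shows a 1.4-fold higher number from compound 2 to compound 3 (0.14 log units; within the scatter) and a 1.7-fold higher number from compound 1 to compound 3 (0.23 log units; within the scatter) so that all three stand within the scatter of one another. Among these compounds, until now the only exchange at this place had run between two aryl groups with a substituent at the 4-position, whereas 2-ethylphenyl has no such group, is built of carbon only and lacks the hydrogen-bond acceptors of 4-methoxy-2-nitrophenyl. Even this exchange, which also takes the aryl group from 11 heavy atoms to 8, gives no step beyond the scatter, so none of these differences can be tied to a change in the number for this series. Nothing measured here accounts for the three aryl groups standing level.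

All the groups shown at this place are substituted phenyl rings, so it remains open whether a phenyl ring bearing an amine or a carboxylic acid would move the number beyond the scatter. On these data alone, it also remains open whether a plain butyl chain in place of the aryl group on this nitrogen would do so, in either direction.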